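The compounds below may be only part of what the source reports. "The series", "measured", "known", "first", "only" and "open" are said of these compounds alone.

In an ADME assay (liver, Mus musculus) for metabolic stability, using microsomes (a higher number here means faster removal of the compound, a lower number slower removal), compound 1 `CN(Cc1ccccc1)C(=O)n1cnc(S(=O)(=O)[C@@H]2C[C@H]3CC[C@@H]2C3)n1` gives 4 mL.min-1.g-1. Within the data shown here, its methoxy counterpart, compound 2 `COc1ccc(CN(C)C(=O)n2cnc(S(=O)(=O)[C@@H]3C[C@H]4CC[C@@H]3C4)n2)cc1`, gives 3 mL.min-1.g-1, so compound 2 stands level with compound 1, the only measured step being a 1.3-fold lower number from compound 1 to compound 2 (0.12 log units; within the scatter). Compound 3 `CN(Cc1ccc(C(C)(C)C)cc1)C(=O)n1cnc(S(=O)(=O)[C@@H]2C[C@H]3CC[C@@H]2C3)n1` carries tert-butyl in place of methoxy on an aromatic carbon, para to a large group: tert-butyl in place of methoxy on an aromatic carbon. Among the measured compounds shown here, that single measured step is the only one bearing on this change, and it is an imperfect guide, since no measured compound carries tert-butyl. Going by the step of a 1.3-fold lower number from compound 1 to compound 2 (0.12 log units; within the scatter), no shift beyond the scatter is expected, though the range is kept wide on the upper side. The expected change is a 1.7-fold higher number from compound 2 to compound 3 (0.22 log units; within the scatter), a step within the scatter. Compound 3 is estimated at 5 mL.min-1.g-1, with an expected range from 2.5 mL.min-1.g-1 to 12 mL.min-1.g-1.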

Compound 3, intrinsic clearance in microsomes in the liver assay: 7.8 mL.min-1.g-1
Estimate against measurement, compound 3: 1.6-fold (0.19 log units) below; the range from low to high includes it.
By their numbers in the liver assay, from the lowest: compounds 2, 1 and 3 (each within the scatter of the next, the first and the last beyond it).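

In the liver assay, this place on the aromatic ring, para to a large group, turns out to be able to move the number beyond the scatter, which the methoxy step had not shown: a 2.6-fold higher number from compound 2 to compound 3 (0.41 log units; beyond the scatter). Measured against hydrogen, the same group gives a smaller step, a 2.0-fold higher number from compound 1 to compound 3 (0.29 log units; within the scatter), so the shift beyond the scatter appears only in the comparison with methoxy. In a physicochemical assay for solubility, measured as kinetic solubility (a lower number here means a less soluble compound, a higher number a more soluble compound), compound 2 gives 125000 nM and compound 3 gives 28000 nM, and the change from methoxy to tert-butyl also has a clear downside: the measured solubility of compound 2, 125000 nM, and of compound 3, 28000 nM, a 4.5-fold lower number (0.65 log units; beyond the scatter)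

With only hydrogen, methoxy and tert-butyl at this place, the compounds shown leave open whether a nitrile or an amine there would keep the liver assay number near that of compound 2. They also leave open whether such a group would preserve the higher number of compound 2 in the physicochemical assay.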